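This account rests on a few compounds, and the source may have more. Where it says the series, first, only, none or still open, it means among the compounds named here.

Working notes on the series. Compound 1 `C=CC1=C(C(=O)NCc2ccccc2)C(c2ccc(OC)c(OC)c2)OC1` is the reference point. In a functional assay on HeLa cells (Homo sapiens) for cytotoxicity, read by MTT assay, with a stated time of 24 h (on this read-out lower numbers stand for stronger inhibition and higher numbers for weaker inhibition), compound 1 gives only a limit, > 100000 nM. Compound 2 `C=CC1=C(C(=O)NCc2ccccc2)C(c2ccc(OC)cc2)OC1` likewise reaches only a limit in this assay, > 100000 nM. Compound 3 `C=CC1=C(C(=O)NC(C)(C)C)C(c2ccc(F)cc2)OC1` also sits at a limit in this assay, > 100000 nM. Among the compounds with values here, the single measured step, a step that the two limits leave unreadable from compound 1 to compound 2, cannot be read because of the limit of > 100000 nM in this assay, at which 3 of the 3 values shown sit. Compound 4 `C=CC1=C(C(=O)Nc2ccccc2)C(c2ccc(OC)c(OC)c2)OC1` differs from compound 1 by phenyl in place of benzyl on an amide-type nitrogen. Within the data shown here, no measured step bears on that change, and none is readable. The expectation for compound 4 therefore rests on the limits alone, so the step of a number no higher from compound 1 to compound 4 (the limit leaves the size open) is expected to stay at the limit. Compound 4 is expected to give 100000 nM in this assay, within 50000 nM to 300000 nM, most likely again reported as a limit.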

Compound 4, half-maximal inhibitory concentration: 5030 nM
For compound 4 the middle estimate is 20-fold (1.30 log units) above the measured one; the measured number lies below the stated range.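

In this assay, within the data shown here, phenyl in place of benzyl on an amide-type nitrogen gives an at least 19-fold lower number from compound 1 to compound 4 (1.29 log units; beyond the scatter) and so yields the first readable step. The amide substituent is thus a place where this read-out responds, which the change on the aromatic ring from compound 1 to compound 2 could not show. Compound 4 is the only compound shown with a number rather than a limit: the limit of > 100000 nM in this assay, at which 3 of the 4 values shown sit.

The compounds shown leave open how a phenethyl or a pyridyl group on the same nitrogen would read. As far as these compounds go, whether anilino keeps this effect with the other aromatic groups of compound 2 and compound 3 also stays open.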